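The source may report more compounds than this note shows. Statements on the series, on what has been measured and on what is new or still open speak of the compounds shown alone.

Compound 1, `CC(C)CCn1c(Cn2c(=O)n(C3CC3)c3ccncc32)nc2nc(Cl)ccc21` — in an ADME assay on HeLa cells (Homo sapiens) for cytotoxicity, read by ATP content, with a stated time of 3 days (on this read-out lower numbers stand for higher toxicity in this test and higher numbers for lower toxicity in this test), compound 1 gives only a limit of the assay, > 50000 nM.
Compound 2, `CC(C)(O)CCCn1c(Cn2c(=O)n(C3CC3)c3ccncc32)nc2nc(Cl)ccc21` — in this assay compound 2 gives a limit as well, > 50000 nM.
Compound 3, `O=c1n(Cc2nc3nc(Cl)ccc3n2CCCCO)c2cnccc2n1C1CC1` — in this assay compound 3 also gives a limit, > 50000 nM.

Compound 3 therefore stands where every measured compound of the series stands: at the limit, with no number of its own. All three values sit at the same place, as the limit of > 50000 nM in this assay, at which 3 of the 3 values shown sit, shows. The steps among the measured compounds are consequently unreadable: a step that the two limits leave unreadable from compound 1 to compound 2, a step that the two limits leave unreadable from compound 1 to compound 3 and a step that the two limits leave unreadable from compound 2 to compound 3 each run from one limit to another and give no size.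

Compound 4, `O=c1n(Cc2nc3nc(Cl)ccc3n2CCCCF)c2cnccc2n1C1CC1`, has not yet been measured in this assay. It differs from compound 3 in one place: fluoro in place of hydroxy on a saturated chain carbon, four bonds along the chain from an aromatic nitrogen. Within the data shown here, no measured step bears on this change, since every step is hidden by the limits. What the data do show is that three compounds sharing the core of compound 3, with different chains, all stay at the limit. The account therefore expects no readable step: a step that the limit leaves unreadable from compound 3 to compound 4. Compound 4 is estimated to give 60000 nM in this assay, with a range from 30000 nM to 120000 nM, and most likely it too is expected to be reported only as a limit.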

Compound 4, half-maximal cytotoxic concentration: > 50000 nM
Compound 4: only a limit was reported (the forecaster's own chance of this, stated with the estimate: 85%); the middle value is on the limit's open side.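

In this assay compound 4 gives > 50000 nM as a limit and not a number. No new step can be read among compounds 1, 2, 3 and 4, which all rest at the same place: the limit of > 50000 nM in this assay, at which 4 of the 4 values shown sit. The compounds shown leave open what chain on the shared core, if any, would give a value short of this limit.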